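A few compounds are considered here, and "the series" means these few. Any claim that something is new, unique, unknown or untested is made for them only; others in the source may bear on it.

Measured so far in an ADME assay on L6 cells (Rattus norvegicus) for cytotoxicity; a lower number here means a stronger inhibitor, a higher number a weaker inhibitor:
- compound 1 `COc1cc2c(cc1C(C)NCCCc1ccccc1)C=CC(C)(C)O2` gives 1080 nM
- compound 2 `COc1ccc(CNC(C)c2cc3c(cc2OC)OC(C)(C)C=C3)cc1` gives 14900 nM
- compound 3 `COc1cc2c(cc1C(C)NC/C=C/c1ccccc1)C=CC(C)(C)O2` gives 14600 nM

Compound 1 holds the lowest number of the three. The steps (a 14-fold higher number from compound 1 to compound 2 (1.14 log units; beyond the scatter)) and (a 14-fold higher number from compound 1 to compound 3 (1.13 log units; beyond the scatter)) are both large and beyond the scatter, while the third (a 1.0-fold lower number from compound 2 to compound 3 (0.01 log units; within the scatter)) stays within it. Compound 4 `COc1cc2c(cc1C(C)N(C)CCCc1ccccc1)C=CC(C)(C)O2` has methyl in place of hydrogen on an amine nitrogen. All three measured steps change the group on a saturated chain carbon bound to an amine nitrogen. None tests the nitrogen itself, and they give only a loose guide. A small rise in this assay is expected, perhaps none beyond the scatter. The estimated step is modest (a 1.4-fold higher number from compound 1 to compound 4 (0.14 log units; within the scatter)). Compound 4 is expected near 1500 nM (estimated range 500 nM to 5000 nM).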

Compound 4, half-maximal inhibitory concentration: 16300 nM
Compound 4: middle estimate off by 11-fold (1.04 log units), on the low side; the measured number lies above the stated range.
By their numbers in this assay, from the lowest: compound 1; then compounds 3, 2 and 4 (each within the scatter of the next).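

In this assay, the amine nitrogen proves as sensitive to change as the group on the saturated chain carbon: methyl in place of hydrogen gives a 15-fold higher number from compound 1 to compound 4 (1.18 log units; beyond the scatter). A single added carbon is enough to lose the low number of compound 1, so that number requires both the phenethyl group and the hydrogen on the nitrogen. Nothing available explains this step.

As far as these compounds go, whether ethyl or acetyl on the nitrogen would behave like methyl remains open. So does whether methyl on the nitrogen has any comparable effect alongside 4-methoxyphenyl or 2-phenylethenyl.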